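Formyl on the fused core of compound 2

The source may report more compounds than this note shows. Statements on the series, on what has been measured and on what is new or still open speak of the compounds shown alone.

Measured compounds:
- compound 1 `Cc1ccc2c(Cc3nn4cc(-c5ccc(Cl)cc5)nc4s3)coc2c1`: 42.1%
- compound 2 `Cc1ccc2c(Cc3nn4cc(-c5ccc(Br)cc5)nc4s3)coc2c1`: 12%
- compound 3 `Cc1ccc2c(Cc3nn4cc(-c5ccc([N+](=O)[O-])cc5)nc4s3)coc2c1`: 24.3%

In a functional assay on the whole organism (strain Wistar albino) for inhibition, with Rattus norvegicus as the target, read by paw edema, with a stated time of 2 h, at a dose of 100 mg/kg by the oral route (on this read-out higher numbers stand for more inhibition at the one dose given (going by the name of the read-out) and lower numbers for less inhibition), compound 2 gives 12%, the lowest of the three measured values. Compound 3 sits nearer, with the step of a number 12.3 percentage points higher from compound 2 to compound 3 (beyond the scatter), and compound 1 furthest, with the step of a number 30.1 percentage points lower from compound 1 to compound 2 (beyond the scatter) read in the opposite direction. All three measured steps, including a number 17.8 percentage points lower from compound 1 to compound 3 (beyond the scatter), concern only the group on the 4-substituted phenyl ring.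

Compound 4 `Cc1ccc2c(Cc3nn4c(C=O)c(-c5ccc(Br)cc5)nc4s3)coc2c1` differs from compound 2 in another place: formyl in place of hydrogen on an aromatic carbon. The entering formyl sits on an aromatic carbon of the five-membered ring with two nitrogens in the fused system, on the ring atom bearing the 4-bromophenyl group's neighbour as given above. Among the compounds with values here, no measured step changes that ring or adds a group of this kind, so none of the three steps bears directly on it.

With nothing in the data to set a direction, compound 4 is expected to stay close to compound 2, the step of a number 4 percentage points higher from compound 2 to compound 4 (within the scatter) being estimated as none beyond the scatter, with a wide range on either side. The estimate for compound 4 in this assay is 16%, between 2% and 38%.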

Compound 4, a percentage reported as inhibition, in the whole organism at one dose (the size of the read-out at that dose, not a potency): 11.2%
Beside the measured number, compound 4's estimate is 4.8 percentage points above it, within the range that was stated.
By their numbers in this assay, from the lowest: compounds 4 and 2 (each within the scatter of the next); then compound 3; then compound 1.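

In this assay, within the data shown here, the only step at the aromatic carbon next to the ring atom that bears a 4-bromophenyl group is a number 0.8 percentage points lower from compound 2 to compound 4 (within the scatter), so formyl in place of hydrogen at this position leaves the read-out unchanged, whereas the earlier steps touched only the group on the phenyl ring. Among these compounds, the step shows that formyl here does not raise the number on the bromo compound, but compound 2 already stands lowest among the earlier compounds, which leaves little room for any further loss to show. No measurement at hand explains this result.

On these data alone, whether formyl at this position would also leave the number unchanged on the chloro compound, compound 1 at 42.1%, remains open. Also open, as far as these compounds go, is what a carboxylic acid or an aminomethyl group would do on this same carbon.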